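This account rests on a few compounds, and the source may have more. Where it says the series, first, only, none or still open, it means among the compounds named here.

Three compounds share one core and differ only in the group on an oxygen on an aromatic ring. In a functional assay on RAW264.7 cells (Mus musculus) for inhibition, read by Griess assay, with stated times of 1 h and 24 h (a higher number here means a weaker inhibitor, a lower number a stronger inhibitor), compound 1 (`COc1cc(OC)c2c(c1)C(C(O)c1ccc(O)cc1)OC2=O`) gives > 10000 nM, which is a limit of the assay and not a number. Compound 2 (`CCC(C)Oc1ccc(C(O)C2OC(=O)c3c(OC)cc(OC)cc32)cc1`) gives > 10000 nM, again a limit. Among the compounds with values here, compound 3 (`COCCCCOc1ccc(C(O)C2OC(=O)c3c(OC)cc(OC)cc32)cc1`) gives 8210 nM, the only true number in the set.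

The next molecule, compound 4 (`C=CCCOc1ccc(C(O)C2OC(=O)c3c(OC)cc(OC)cc32)cc1`), keeps that core and changes only the end of the chain, so that 4-methoxybutyl becomes but-3-en-1-yl: vinyl in place of 2-methoxyethyl on a saturated chain carbon, two bonds along the chain from an oxygen on an aromatic ring.

The measured steps that bear on this change all alter the same group on that oxygen. They are a step that the two limits leave unreadable from compound 1 to compound 2, an at least 1.2-fold lower number from compound 1 to compound 3 (0.08 log units; that floor lies within the scatter), and an at least 1.2-fold lower number from compound 2 to compound 3 (0.08 log units; that floor lies within the scatter). Their sizes are poorly defined because of the limit of > 10000 nM in this assay, at which 2 of the 3 values shown sit. None of them shows a change beyond the scatter, so no step beyond the scatter is expected in this assay, in either direction.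

Within the data shown here, the estimate therefore starts from compound 3 at 8210 nM, the one real number available. The expected move is a 1.1-fold higher number from compound 3 to compound 4 (0.04 log units; within the scatter). For compound 4 the estimated value is 9000 nM, with an expected range of 4500 nM to 18000 nM.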

Compound 4, half-maximal inhibitory concentration: 1330 nM
Compound 4: the middle estimate sits 6.8-fold (0.83 log units) above what was measured; measured number below the stated range.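

In this assay the change at the end of the chain gives a 6.2-fold lower number from compound 3 to compound 4 (0.79 log units; beyond the scatter) and this is the first step in the set that is shown to lie beyond the scatter, so what sits at this place, two bonds along the chain from an oxygen on an aromatic ring, can clearly move the number. Compound 4 also stands apart from the two compounds held at a limit, with an at least 7.5-fold lower number from compound 2 to compound 4 (0.87 log units; beyond the scatter) and with an at least 7.5-fold lower number from compound 1 to compound 4 (0.87 log units; beyond the scatter) but these sizes are only floors because of one feature of the data: the limit of > 10000 nM in this assay, at which 2 of the 4 values shown sit. The change from compound 3 to compound 4 swaps 2-methoxyethyl, with 4 heavy atoms and 1 hydrogen-bond acceptor, for vinyl, with 2 heavy atoms, 1 double bond and 0 hydrogen-bond acceptors, so these differences all arrive together.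

On these data alone, what a plain saturated butyl chain would give remains open, and that group would separate the double bond from the loss of the chain oxygen. As far as these compounds go, whether a longer chain ending in vinyl, or an amine at the chain end, would shift the number further also stays open.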